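Adding an Amino Group to the Lowest-Numbered Pyridine

The source may report more compounds than this note shows. Statements on the series, on what has been measured and on what is new or still open speak of the compounds shown alone.

Going by the values given here, in a functional assay for antagonist activity at metabotropic glutamate receptor 5 (Rattus norvegicus) (on this read-out higher numbers stand for weaker inhibition and lower numbers for stronger inhibition), compound 2 `Fc1cc(-c2ccccn2)cc(-n2nnc(-c3ccccn3)n2)c1` gives 39 nM, the lowest of the three numbers measured so far. Compound 1 `Cc1ccccc1-c1cc(F)cc(-n2nnc(-c3ccccn3)n2)c1` gives 120 nM and compound 3 `Cc1cnccc1-c1cc(F)cc(-n2nnc(-c3ccccn3)n2)c1` gives 63 nM. The step of a 3.1-fold lower number from compound 1 to compound 2 (0.49 log units; beyond the scatter) lies beyond the scatter, whereas a 1.9-fold lower number from compound 1 to compound 3 (0.28 log units; within the scatter) and a 1.6-fold higher number from compound 2 to compound 3 (0.21 log units; within the scatter) stay within it. Compound 4 `Nc1cccnc1-c1cc(F)cc(-n2nnc(-c3ccccn3)n2)c1` differs from compound 2 by amino in place of hydrogen on an aromatic carbon. Among the compounds with values here, none of the measured steps adds a group to this ring; each exchanges one whole aryl group for another, so they give no direct guide for this change. Compound 4 is therefore expected to show a step of a 1.2-fold higher number from compound 2 to compound 4 (0.06 log units; within the scatter), no larger than the scatter. In this assay compound 4 is estimated at 45 nM, within 15 nM to 140 nM.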

Compound 4, half-maximal inhibitory concentration: 19 nM
Estimate against measurement, compound 4: 2.4-fold (0.37 log units) above, and the stated range covers the measured number.
By their numbers in this assay, from the lowest: compound 4; then compounds 2, 3 and 1 (each within the scatter of the next, the first and the last beyond it).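

In this assay, amino on an aromatic carbon ortho to a large group, two atoms from the ring nitrogen, lowers the number (a 2.1-fold lower number from compound 2 to compound 4 (0.31 log units; beyond the scatter)), so this position accepts an added group without loss. The 3-aminopyridin-2-yl group also sits clear of the other two aryl groups (a 3.3-fold lower number from compound 3 to compound 4 (0.52 log units; beyond the scatter); a 6.3-fold lower number from compound 1 to compound 4 (0.80 log units; beyond the scatter)). No measurement at hand bears on the reason for this drop.

From the compounds shown here alone, whether a hydroxyl, a methoxy or a methylamino group at this position would lower the number as well remains open. So does the effect of amino elsewhere on this ring.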